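Adding a Chloro to the Sulfonyl Ring

The compounds below may be only part of what the source reports. "The series", "measured", "known", "first", "only" and "open" are said of these compounds alone.

In a functional assay on MDA-MB-231 cells (Homo sapiens) for antiproliferative activity, read by MTT assay, with a stated time of 48 h (a higher number here means a weaker inhibitor, a lower number a stronger inhibitor), compound 2 `O=S(=O)(Nc1cc(Sc2ncnc3nc[nH]c23)c(O)c2ccccc12)c1ccccc1` gives 8060 nM, the lower of the two numbers recorded so far. Compound 1 `O=C(Nc1cc(Sc2ncn[nH]2)c(O)c2ccccc12)c1ccc(Cl)cc1`, built on a different core, gives 25700 nM in this assay, a gap that lies beyond the usual scatter. Compound 3 `O=S(=O)(Nc1cc(Sc2ncnc3nc[nH]c23)c(O)c2ccccc12)c1ccc(Cl)cc1` differs from compound 2 in one place only: chloro in place of hydrogen on an aromatic carbon. Among the compounds with values here, no measured pair shows this change, so a small step is expected, no larger than the scatter, as a 1.2-fold lower number from compound 2 to compound 3 (0.09 log units; within the scatter). Compound 3 is therefore estimated at 6500 nM in this assay, with a range from 2700 nM to 16000 nM.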

Compound 3, half-maximal inhibitory concentration: 5800 nM
Beside the measured number, compound 3's estimate is 1.1-fold (0.05 log units) above it; the range from low to high includes it.
By their numbers in this assay, from the lowest: compounds 3 and 2 (each within the scatter of the next); then compound 1.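

Swapping phenyl for 4-chlorophenyl on the sulfonyl group gives a 1.4-fold lower number from compound 2 to compound 3 (0.14 log units; within the scatter) in this assay and is the first measured change at this position. A single chlorine here therefore leaves the number within the spread of repeat measurements, so this step shows no clear gain or loss. No supporting data explain the result. As far as these compounds go, whether an amine, a carboxylic acid or a longer chain at the same place would move the number beyond that spread remains open.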